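Moving the bromine on the bromophenyl group

The source may hold more compounds than are shown below. What is called first, only, known or untested is meant among the compounds shown, and "the series" means these compounds.

Compound 1 `O=C1Nc2ccc(Br)cc2/C1=N/NC(=S)N/N=C/c1ccccc1Br`: in a functional assay on HeLa cells (Homo sapiens) for inhibition, read by MTT assay (on this read-out lower numbers stand for stronger inhibition and higher numbers for weaker inhibition), compound 1 gives > 50000 nM, which is a limit of the assay rather than a number.
Compound 2 `Cc1ccc2c(c1)/C(=N/NC(=S)N/N=C/c1ccccc1Br)C(=O)N2`: compound 2 gives > 50000 nM, again a limit.
Compound 3 `COc1ccc(/C=N/NC(=S)N/N=C2\C(=O)Nc3ccc(C)cc32)c(OC)c1`: compound 3 gives > 50000 nM, again a limit.

Compound 2 therefore stands at the limit of this assay, and so do the two other measured compounds: the limit of > 50000 nM in this assay, at which 3 of the 3 values shown sit. For the measured compounds named here, the one step between compounds that differ in a single place, a step that the two limits leave unreadable from compound 1 to compound 2, cannot be given a size because the limit of > 50000 nM in this assay, at which 3 of the 3 values shown sit, holds both of its ends. Compound 3 differs from compound 2 in more than one place, so its value shows only that it, too, sits at the limit.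

Compound 4 `Cc1ccc2c(c1)/C(=N/NC(=S)N/N=C/c1ccc(Br)cc1)C(=O)N2` is the next compound to be measured. It differs from compound 2 by 4-bromophenyl in place of 2-bromophenyl on a carbon with a double bond to nitrogen. Going by the values given here, no measured step touches this kind of change, a shift of the bromine within the same ring, so nothing in the data points in either direction. Given that every measured value is a limit, compound 4 is expected to give 60000 nM, with an estimated range from 15000 nM to 200000 nM. This estimate means an expected step that the limit leaves unreadable from compound 2 to compound 4, most likely another limit.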

Compound 4, half-maximal inhibitory concentration: > 50000 nM
Compound 4 ended at the assay's limit; the forecaster's own chance of this, stated with the estimate: 80%; the middle value does not contradict the limit.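

Compound 2 and compound 4 each give only a limit in this assay and not a number, so the change from 2-bromophenyl to 4-bromophenyl has no readable size: the limit of > 50000 nM in this assay, at which 4 of the 4 values shown sit. The compounds shown leave open whether the position of the bromine affects inhibition at all, since none of them gives a measurable value.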